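The compounds below may be only part of what the source reports. "The series", "measured", "known", "first", "only" and "open" are said of these compounds alone.

Series notes. Compound 1 `ClCc1ccc(Cn2cnc3c(Cl)ncnc32)cc1` is measured only in a functional assay on K562 cells (Homo sapiens) for cytotoxicity, read by sulforhodamine B assay, with a stated time of 48 h (a higher number here means that more compound is tolerated, a lower number that less compound is tolerated), where compound 1 gives > 100000 nM, a limit of the assay rather than a number. Compound 2 `Nc1nc(Cl)c2ncn(Cc3ccccc3CCl)c2n1` gives > 100000 nM in this assay, again a limit. Compound 1 thus stands at the limit of > 100000 nM in this assay, at which 2 of the 2 values shown sit. Compound 3 `ClCc1ccc(Cn2cnc3c(Cl)nc(Cl)nc32)cc1` is not yet measured; it differs from compound 1 by chloro in place of hydrogen on an aromatic carbon. For the measured compounds named here, no step between measured compounds exists to size this change, so no shift beyond the scatter is assumed. The expected step of a number no higher from compound 1 to compound 3 (the limit leaves the size open) is taken as none in either direction. Compound 3 is estimated at 100000 nM, between 30000 nM and 300000 nM, most likely reported again as a limit.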

Compound 3, concentration lethal to 50% of the cells: > 100000 nM
Compound 3: no number, only a limit (the forecaster's own chance of this, stated with the estimate: 80%); the middle value sits exactly at the limit.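

Compound 1 and compound 3 both sit at a limit of this assay, so no step can be read for chloro in place of hydrogen on an aromatic carbon. The compounds shown leave open whether this chloro changes cytotoxicity at all, and at what concentration any of them would reach the read-out: the limit of > 100000 nM in this assay, at which 3 of the 3 values shown sit.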